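A few compounds are considered here, and "the series" means these few. Any claim that something is new, unique, unknown or untested is made for them only; others in the source may bear on it.

Working notes on the series of compound 1 `COc1ccc(-c2cc(=O)c3c(OC)cc(OC)cc3[nH]2)cc1` and compound 2 `COc1ccc(-c2cc(=O)c3c(OC)cc(OC)cc3n2S(=O)(=O)c2ccc(C=O)cc2)cc1` in a functional assay on KOPN-8 cells (Homo sapiens) for antiproliferative activity, with a stated time of 72 h; a lower number here means that less compound is needed, a higher number that more compound is needed for the effect. For compound 1 the read-out is only a limit of the assay, > 31100 nM. For compound 2 the read-out is likewise a limit, > 34400 nM. Within the data shown here, the single measured step, a step that the two limits leave unreadable from compound 1 to compound 2, thus has no readable size, since both ends rest on limits (the limit of > 31100 nM in this assay, at which 1 of the 2 values shown sits, (the limit of > 34400 nM in this assay, at which 1 of the 2 values shown sits)). Compound 2 therefore stands at a limit alone, with no number to rank it by.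

Compound 3 `COc1ccc(-c2cc(=O)c3c(OC)cc(OC)cc3n2S(=O)(=O)c2c(F)c(F)c(F)c(F)c2F)cc1` differs from compound 2 by 2,3,4,5,6-pentafluorophenyl in place of 4-formylphenyl on a sulfonyl sulfur. Among the measured compounds shown here, the only measured step concerns the group on an aromatic nitrogen, not the ring on a sulfonyl sulfur, and its size is unreadable, so it offers no guide for this change. With both measured compounds at limits, compound 3 is expected to stay at a limit as well. Compound 3 is accordingly expected to show a step that the limit leaves unreadable from compound 2 to compound 3 within the scatter. The estimate for compound 3 is 35000 nM, within a range from 10000 nM to 120000 nM.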

Compound 3, half-maximal effective concentration: > 34400 nM
Compound 3 ended at the assay's limit; the forecaster's own chance of this, stated with the estimate: 80%; the middle value does not contradict the limit.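

Among these compounds, compound 2 and compound 3 both rest on limits of the assay, so no step between them can be read. The compounds shown leave open whether any group on the aromatic nitrogen or the sulfonyl sulfur gives a measurable effect in this assay.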